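Adding trifluoromethyl to compound 2

This account rests on a few compounds, and the source may have more. Where it says the series, first, only, none or still open, it means among the compounds named here.

In a functional assay on L1210 cells (Mus musculus) for inhibition (on this read-out higher numbers stand for weaker inhibition and lower numbers for stronger inhibition), compound 2 (`C#CCN(Cc1ccc2nc(C)nc(O)c2c1)c1ccc([N+](=O)[O-])cc1`) gives 4700 nM as the lower of the two exact numbers. Compound 3 (`C#CCN(Cc1ccc2nc(C)nc(O)c2c1)c1ccc(S(N)(=O)=O)cc1`) gives 20000 nM as the other. Compound 1 (`C#CCN(Cc1ccc2nc(C)nc(O)c2c1)c1ccc(C#N)cc1`) shows > 5000 nM and this is a limit of the assay, not a number. Compound 4 (`C#CCN(Cc1ccc2nc(C)nc(O)c2c1)c1ccc([N+](=O)[O-])c(C(F)(F)F)c1`) has trifluoromethyl in place of hydrogen on an aromatic carbon, ortho to a nitro group: trifluoromethyl in place of hydrogen on an aromatic carbon is the whole change. The measured steps only swap one group for another: an at least 1.0-fold lower number from compound 1 to compound 2 (0.02 log units; that floor lies within the scatter) says little, and a 4.3-fold higher number from compound 2 to compound 3 (0.63 log units; beyond the scatter) is modest. Neither adds a group to a hydrogen-bearing carbon, so no direction can be favoured. The expected outcome in this assay is a 1.1-fold higher number from compound 2 to compound 4 (0.03 log units; within the scatter) and no more. For compound 4 the estimated value is 5000 nM with an expected range of 1800 nM to 15000 nM overall.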

Compound 4, half-maximal inhibitory concentration: 5000 nM
Beside the measured number, compound 4's estimate shows no gap at the digits printed, within the range that was stated.
By their numbers in this assay, from the lowest: compounds 2 and 4 (each within the scatter of the next); then compound 3.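

Trifluoromethyl on an aromatic carbon, ortho to a nitro group, gives a 1.1-fold higher number from compound 2 to compound 4 (0.03 log units; within the scatter) in this assay. The earlier steps shown here only swapped one group for another, whereas this one adds four heavy atoms at a carbon that carried hydrogen, and the number does not readably move. The value for compound 1 is a limit of the assay, not a number: the limit of > 5000 nM in this assay, at which 1 of the 4 values shown sits.

Going by these compounds, whether a methyl, a chlorine or an amine at this same carbon would leave the number equally unmoved stays open. So does whether trifluoromethyl behaves alike with sulfamoyl in place of the nitro group.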